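Amide-side variation in an inactive cytotoxicity series

The source may report more compounds than this note shows. Statements on the series, on what has been measured and on what is new or still open speak of the compounds shown alone.

Of the compounds shown here, three have been measured in a functional assay on HeLa cells (Homo sapiens) for cytotoxicity, read by MTT assay, with a stated time of 24 h (on this read-out lower numbers stand for stronger inhibition and higher numbers for weaker inhibition), and none gave a number. Compound 1 `C=CC1=C(C(=O)NCc2ccc(Cl)cc2)C(c2ccc(OC)c(OC)c2)OC1` reaches only the limit > 100000 nM. Compound 2 `C=CC1=C(C(=O)NCc2ccc(Cl)cc2)C(c2ccc(OC)cc2)OC1` likewise stops at the limit > 100000 nM. Compound 3 `C=CC1=C(C(=O)NCc2ccc(C)cc2)C(c2ccc(OC)c(OC)c2)OC1` also returns the limit > 100000 nM. The two single-point steps are therefore unreadable: a step that the two limits leave unreadable from compound 1 to compound 2 and a step that the two limits leave unreadable from compound 1 to compound 3. The whole picture so far is summed up by the limit of > 100000 nM in this assay, at which 3 of the 3 values shown sit.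

Compound 4 `C=CC1=C(C(=O)Nc2ccccc2)C(c2ccc(OC)cc2)OC1` is the next member to be measured. It differs from compound 2 in one place: phenyl in place of 4-chlorobenzyl on an amide-type nitrogen. Within the data shown here, no measured step in this assay concerns the amide-type nitrogen, and the two steps that exist, on the aromatic carbons of the other ring and of the benzyl group, both sit between limits, so they give no direction and no size. The expectation for the step from compound 2 to compound 4 is therefore none beyond the scatter, written as a step that the limit leaves unreadable from compound 2 to compound 4, with a strong chance that the limit is reached again. For compound 4 the estimated value in this assay is 150000 nM, with a range from 40000 nM to 600000 nM.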

Compound 4, half-maximal inhibitory concentration: > 100000 nM
Compound 4 ended at the assay's limit (the forecaster's own chance of this, stated with the estimate: 80%); the middle value is on the limit's open side.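

Compound 2 and compound 4 both end at a limit, so the step between them cannot be read, and the series stands thus: the limit of > 100000 nM in this assay, at which 4 of the 4 values shown sit.

Still open, on these data alone, is whether any change on the amide side or the aromatic rings gives a measurable value.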